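The compounds below may be only part of what the source reports. "The series", "measured", "known", "first", "only" and "open" are said of these compounds alone.

- Compound 1 (`CC(C)(C)CC#Cc1cc2ncnc(Nc3ccc(OCc4cccc(F)c4)c(Cl)c3)c2s1`) gives 29.3 uM
- Compound 2 (`CCCN(CC#Cc1cc2ncnc(Nc3ccc(OCc4cccc(F)c4)c(Cl)c3)c2s1)CCC`) gives 26.5 uM
- Compound 3 (`CCOC(=O)CN(C)CC#Cc1cc2c(Nc3ccc(OCc4cccc(F)c4)c(Cl)c3)ncnc2s1`) gives > 28 uM as a limit, not a number

All three readings come from an ADME assay on HepG2 cells (Homo sapiens) for cytotoxicity (a higher number here means that more compound is tolerated, a lower number that less compound is tolerated), and can be set side by side. Compound 3 stands at the limit of > 28 uM in this assay, at which 1 of the 3 values shown sits, and so has no exact number. Compound 1 and compound 2 both give numbers, and these lie within the scatter of each other.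

Compound 4 (`Fc1cccc(COc2ccc(Nc3ncnc4sc(C#CCN5CCCC5)cc34)cc2Cl)c1`) has not yet been measured. It shares the core of compound 3 and differs by one change, pyrrolidin-1-yl in place of ((ethoxycarbonyl)methyl)(methyl)amino on a saturated chain carbon bound to a triple-bonded carbon at the end of the chain.

Going by the values given here, only one measured step touches that place, dipropylamino in place of tert-butyl, and it is a 1.1-fold lower number from compound 1 to compound 2 (0.04 log units; within the scatter) on a core arranged a little differently from that of compound 3, so no step beyond the scatter is expected in this assay for compound 4. The estimated step is an at least 1.0-fold lower number from compound 3 to compound 4 (0.03 log units; that floor lies within the scatter) and it is counted from a limit, so it is only rough. Compound 4 is expected at an estimated 26 uM with a range from 14 uM to 45 uM as the likely bounds.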

Compound 4, half-maximal toxic concentration: > 30 uM
Compound 4 was reported as a limit; the forecaster's own chance of this, stated with the estimate: 25%; middle value at least 1.1-fold (0.06 log units) from the limit.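

In this assay compound 3 gives > 28 uM, which is a limit and not a number. Going by these compounds alone, compound 4 gives > 30 uM, which is also a limit, and no step between compound 3 and compound 4 can be read. The compounds shown leave open whether pyrrolidin-1-yl in place of ((ethoxycarbonyl)methyl)(methyl)amino changes the half-maximal toxic concentration at all.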